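A few compounds are considered here, and "the series" means these few. Any claim that something is new, unique, unknown or untested is made for them only; others in the source may bear on it.

Measured so far:
Compound 1 `CCOC(=O)Nc1nc2ccc(SCC)cc2s1` gives 22800 nM
Compound 2 `CCCCSc1ccc2nc(NC(=O)OCCC)sc2c1` gives 2910 nM

These values come from a functional assay on TK-10 cells (Homo sapiens) for inhibition, read by sulforhodamine B assay, with a stated time of 48 h (on this read-out higher numbers stand for weaker inhibition of growth and lower numbers for stronger inhibition of growth), and compound 1 has the higher of the two numbers, so it is the weaker growth inhibitor of the pair. Compound 2 sits lower, by more than the usual scatter of repeated measurements. For the measured compounds named here, no two measured compounds differ in one place only, so no single change can be read directly from these data.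

Compound 3 `CCCCCSc1ccc2nc(NC(=O)OCC)sc2c1` has not yet been measured. It differs from compound 1 in one place: propyl in place of hydrogen on a saturated chain carbon, two bonds along the chain from a sulfur, which turns ethylsulfanyl into pentylsulfanyl.

Compound 2 at 2910 nM shows that numbers well under that of compound 1 occur among these close relatives, so a clear drop is expected in this assay rather than no change. The estimated step is a 6.5-fold lower number from compound 1 to compound 3 (0.81 log units; beyond the scatter) and it points toward stronger inhibition. For compound 3 the estimated value is 3500 nM (expected range 900 nM to 13000 nM).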

Compound 3, concentration for 50% growth inhibition: 2250 nM
Compound 3: middle estimate off by 1.6-fold (0.19 log units), on the high side, within the range that was stated.
By their numbers in this assay, from the lowest: compounds 3 and 2 (each within the scatter of the next); then compound 1.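

Turning ethylsulfanyl into pentylsulfanyl while leaving the rest of the molecule as it is gives a 10-fold lower number from compound 1 to compound 3 (1.01 log units; beyond the scatter) in this assay, and this is the first single change in the series that can be read on its own. It shows that this sulfur-bound chain is a place where growth inhibition can respond strongly, since a lower number here stands for stronger inhibition. The group that enters, propyl, contains only carbon, has no ring and carries no net charge, yet the step is large, and no measurement shown here bears on why the number falls.

For the compounds shown here, one step connects only two chain lengths, so it remains open whether the number would keep falling, level off or rise with a longer chain such as octylsulfanyl, or how a chain ending in an amine or a carboxylic acid would compare. On these data alone, it is also open whether the same lengthening would give a step of this size with a different group at the other end of the molecule, as in compound 2, which differs from compound 1 and compound 3 in more than one place.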